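The source may hold more compounds than are shown below. What is called first, only, known or untested is meant among the compounds shown, and "the series" means these compounds.

Measured compounds in an assay on isolated protein for inhibition of DNA topoisomerase 1 (Homo sapiens), with a stated time of 30 min, tested at 20 uM; a higher number here means a stronger effect of the compound at the concentration tested, a lower number a weaker effect:
- compound 1 `O=c1[nH]c(-c2cccc3ccccc23)nc2ccc(N3CCCCC3)cc12` gives 33.4%
- compound 2 `COc1cccc(-c2nc3cc(C)ccc3c(=O)[nH]2)c1` gives 80%
- compound 3 `Cc1ccc2nc(-c3ccccc3C(F)(F)F)[nH]c(=O)c2c1` gives 21.1%

Compound 3 stands lowest of the three numbers in this assay. Its nearest neighbour is compound 1, whose inhibition lies higher by a margin beyond the usual scatter; the furthest is compound 2, whose inhibition lies far higher, again beyond the scatter. None of these three pairs differs in only one place, so the gaps between them are simply what the values show and carry no single structural reading.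

Compound 4 `Cc1ccc2nc(-c3ccccc3N(C)C)[nH]c(=O)c2c1` is the next compound to be measured in this assay. It shares its core with compound 3 and differs from it in one place: dimethylamino in place of trifluoromethyl on an aromatic carbon. No step between two measured compounds with this same change is available, so the expected size of the step rests on the spread of the three numbers shown rather than on a direct precedent.

Given that compound 3 sits at the bottom of the series, an upward step of modest size in this assay is expected, not certain to clear the scatter. The expected step is a number 13.9 percentage points higher from compound 3 to compound 4 (beyond the scatter). Compound 4 is therefore estimated at 35%, with a range from 10% to 65%.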

Compound 4, a percentage reported as inhibition, at one concentration (the size of the read-out at that concentration, not a potency): 21.1%
The estimate for compound 4 lay 13.9 percentage points above the measured number; the measured number falls inside the stated range.
By their numbers in this assay, from the lowest: compounds 3 and 4 (each within the scatter of the next); then compound 1; then compound 2.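

In this assay, dimethylamino in place of trifluoromethyl on an aromatic carbon, ortho to a large group, gives no change at the digits printed from compound 3 to compound 4 (within the scatter). Within the data shown here, this is the first one-place step, and it shows that at this position, on this core, two groups that differ in their atoms read alike: compound 3 gives 21.1% and compound 4 gives 21.1%, even though fluorine leaves, nitrogen enters and 1 hydrogen-bond acceptor comes in with the dimethylamino. No measurement shown accounts for this match between the two compounds.

Going by these compounds, whether the reading at this aromatic carbon holds for other groups stays open, for example a carboxylic acid, a primary amine or a nitrile in the same place, since two groups alone cannot show how far the position tolerates change. Also open, on these data alone, is whether dimethylamino in place of trifluoromethyl would read the same way on another member of the series, as this single pair offers no second instance of the change.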